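Swapping One Hydroxyphenyl for Another on the Shared Core

The compounds below may be only part of what the source reports. "The series", "measured", "known", "first", "only" and "open" are said of these compounds alone.

Measured so far in a functional assay on T47D cells (Homo sapiens) for inhibition; a higher number here means a weaker inhibitor, a lower number a stronger inhibitor:
Compound 1, `Oc1cccc(-c2cc(-c3cccc(F)c3)cc(-c3ccccc3O)n2)c1`: compound 1 gives only a limit, > 50000 nM.
Compound 2, `Oc1ccc(-c2cc(-c3cccc(F)c3)cc(-c3cccc(O)c3)n2)cc1`: compound 2 gives 3510 nM.
Compound 3, `Oc1ccc(-c2cc(-c3ccc(F)cc3)cc(-c3cccc(O)c3)n2)cc1`: compound 3 gives 5000 nM.

Compound 2 holds the lowest of the two real numbers, with compound 3 close by: a 1.4-fold higher number from compound 2 to compound 3 (0.15 log units; within the scatter). The value of compound 1 is a limit of the assay, not a number (the limit of > 50000 nM in this assay, at which 1 of the 3 values shown sits).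

Compound 4, `Oc1ccc(-c2cc(-c3cccc(F)c3)cc(-c3ccc(O)cc3)n2)cc1`, differs from compound 2 in one group: 4-hydroxyphenyl in place of 3-hydroxyphenyl on an aromatic carbon. Both rings carry one hydroxyl, so the change is where the hydroxyl sits, not what is present. Among the compounds with values here, the one measured step that also swaps one hydroxyphenyl for another is an at least 14-fold lower number from compound 1 to compound 2 (1.15 log units; beyond the scatter), which was large. Here, however, it is a 3-hydroxyphenyl rather than a 2-hydroxyphenyl that leaves, and the step of a 1.4-fold higher number from compound 2 to compound 3 (0.15 log units; within the scatter) shows that a comparable swap of fluorophenyl groups stayed within the scatter. A modest step at most is therefore expected, a 1.4-fold lower number from compound 2 to compound 4 (0.15 log units; within the scatter), leaning slightly toward a lower number. Compound 4 is estimated at 2500 nM, with a likely range from 700 nM to 9000 nM.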

Compound 4, half-maximal inhibitory concentration: > 50000 nM
Compound 4: a limit, no number; the forecaster's own chance of this, stated with the estimate: 5%; at least 20-fold (1.30 log units) between middle value and limit.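

Moving one hydroxyl, with the same atoms in the molecule, is not a quiet change at this position next to the ring nitrogen: in this assay the step is an at least 14-fold higher number from compound 2 to compound 4 (1.15 log units; beyond the scatter). The 4-hydroxyphenyl group also entered in the earlier step, an at least 14-fold lower number from compound 1 to compound 2 (1.15 log units; beyond the scatter), so the same group goes with a lower number there, where it replaces a 2-hydroxyphenyl group, and a higher one here, where it replaces a 3-hydroxyphenyl group. The result for compound 4 is a limit of the assay, not a number, and it is the second such result: the limit of > 50000 nM in this assay, at which 2 of the 4 values shown sit.

As far as these compounds go, how far compound 4 really lies from compound 2 therefore stays open. Also open, from the compounds shown here alone, is whether the hydroxyl itself matters here or only where it sits, which a methoxy or an amino group on the same ring would help to tell.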